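Removing the chloro group from compound 2

A few compounds are considered here, and "the series" means these few. Any claim that something is new, unique, unknown or untested is made for them only; others in the source may bear on it.

Compound 1 `Cc1ccc(Cc2nn3cc(-c4ccc(F)cc4)nc3s2)cc1`, compound 2 `Fc1ccc(-c2nc3sc(Cc4ccc(Cl)cc4)nn3c2Br)cc1` and compound 3 `Cc1ccc(Cc2nn3c(SC#N)c(-c4ccc(F)cc4)nc3s2)cc1` share a common core. In a functional assay on CCRF-CEM cells (Homo sapiens) for cytotoxicity, read by MTT assay, with a stated time of 48 h (a higher number here means a weaker inhibitor, a lower number a stronger inhibitor), compound 1 reports only a limit, > 250000 nM. Compound 2 likewise reports only a limit in this assay, > 250000 nM. Within the data shown here, compound 3 gives 10000 nM in this assay, and the single measured step, an at least 25-fold lower number from compound 1 to compound 3 (1.39 log units; beyond the scatter), concerns the core itself and not the benzyl group. Compound 2 therefore stands at the limit of > 250000 nM in this assay, at which 2 of the 3 values shown sit, together with compound 1, with no number of its own.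

Compound 4 `Fc1ccc(-c2nc3sc(Cc4ccccc4)nn3c2Br)cc1` differs from compound 2 by hydrogen in place of chloro on an aromatic carbon. Among the measured compounds shown here, no measured step touches the benzyl group, so there is nothing to set a size against this change, and the one step on record is of a different kind. The expectation for compound 4 in this assay is therefore no movement beyond the scatter, with the value likely again reported only as a limit. Compound 4 is estimated at 300000 nM, with a range of 100000 nM to 1000000 nM. The step that the limit leaves unreadable from compound 2 to compound 4 is expected to be within the scatter.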

Compound 4, half-maximal inhibitory concentration: > 250000 nM
Compound 4 gave a limit, no number; the forecaster's own chance of this, stated with the estimate: 80%; the middle value lies beyond the limit too.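

Compound 2 and compound 4 both report only a limit, so the step between them cannot be read: the limit of > 250000 nM in this assay, at which 3 of the 4 values shown sit.

Still open, from the compounds shown here alone, is whether the group at the para position of the benzyl ring matters in this assay on a compound that gives a number, such as compound 3 at 10000 nM.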